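Methoxy to hydrogen on compound 2

The source may report more compounds than this note shows. Statements on the series, on what has been measured and on what is new or still open speak of the compounds shown alone.

Compound 1 `Nc1nc(Nc2ccc(S(N)(=O)=O)cc2)sc1C(=O)c1ccccc1[N+](=O)[O-]` gives 16000 nM in a functional assay on TM4 cells (Mus musculus) for cytotoxicity, read by MTT assay, with a stated time of 72 h; on this read-out lower numbers stand for stronger inhibition and higher numbers for weaker inhibition
Compound 2 `COc1cccc(C(=O)c2sc(Nc3ccc(S(N)(=O)=O)cc3)nc2N)c1` gives 6400 nM in this assay

For the measured compounds named here, compound 2 holds the lower of the two numbers so far. Compound 3 `Nc1nc(Nc2ccc(S(N)(=O)=O)cc2)sc1C(=O)c1ccccc1` has hydrogen in place of methoxy on an aromatic carbon, meta to a large group (hydrogen in place of methoxy on an aromatic carbon), so that 3-methoxyphenyl becomes phenyl. Going by the values given here, only one measured step bears on this: a 2.5-fold lower number from compound 1 to compound 2 (0.40 log units; beyond the scatter) (modest), which changes the same aryl group on the carbonyl carbon. Among the compounds with values here, that step exchanges a different pair of groups, and no measured pair isolates the methoxy. A small to modest rise in this assay is therefore expected, though a step within the scatter would not surprise. For compound 3 the expected change is a 1.4-fold higher number from compound 2 to compound 3 (0.15 log units; within the scatter) (an estimate). Compound 3 is estimated at 9000 nM (expected range 3500 nM to 20000 nM).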

Compound 3, half-maximal inhibitory concentration: 9100 nM
Beside the measured number, compound 3's estimate is 1.0-fold (0.00 log units) below it; the measured number falls inside the stated range.
By their numbers in this assay, from the lowest: compounds 2, 3 and 1 (each within the scatter of the next, the first and the last beyond it).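

In this assay, for the compounds shown here, compound 3 gives the first direct reading of the methoxy, since hydrogen in its place gives a 1.4-fold higher number from compound 2 to compound 3 (0.15 log units; within the scatter); on this aromatic carbon, meta to a large group, the read-out does not separate methoxy from hydrogen. Hydrogen in place of nitro gives a 1.8-fold lower number from compound 1 to compound 3 (0.25 log units; within the scatter), so neither substituted compound stands apart from the phenyl compound, even though the step between them, a 2.5-fold lower number from compound 1 to compound 2 (0.40 log units; beyond the scatter), lies beyond the scatter. No other data bear on the reason for these numbers.

On these data alone, it remains open whether an amine or a carboxylic acid on this aromatic carbon would give a step beyond the scatter from the phenyl compound. The compounds shown vary only the aryl group on the carbonyl, so the other parts of the shared core remain unexplored here.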